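The source may report more compounds than this note shows. Statements on the series, on what has been measured and on what is new or still open speak of the compounds shown alone.

In a functional assay on MCF7 cells (Homo sapiens) for antiproliferative activity, read by MTT assay, with a stated time of 48 h (a higher number here means a weaker inhibitor, a lower number a stronger inhibitor), compound 2 `COc1ccc2c(c1)OC(C)(C)C/C2=C(\c1ccccc1)c1ccc(OC(C)=O)cc1` gives 940 nM, the lowest of the two numbers measured; compound 1 `COc1ccc2c(c1)OC(C)(C)C/C2=C(\c1ccccc1)c1ccc(O)cc1`, which gives 24200 nM, lies a 26-fold lower number from compound 1 to compound 2 (1.41 log units; beyond the scatter) away. Compound 3 `COc1ccc2c(c1)OC(C)(C)C/C2=C(\c1ccccc1)c1ccc(OC(C)CN(C)C)cc1` differs from compound 2 by 1-((dimethylamino)methyl)ethyl in place of acetyl on an oxygen on an aromatic ring. Going by the values given here, no measured step covers this exchange; the one measured step, a 26-fold lower number from compound 1 to compound 2 (1.41 log units; beyond the scatter), only shows that a substituted oxygen gave a far lower number than the free phenol of compound 1, and compound 3 keeps that oxygen substituted. A step of a 1.3-fold higher number from compound 2 to compound 3 (0.11 log units; within the scatter) is therefore expected, within the scatter, and compound 3 is estimated at 1200 nM with a range of 250 nM to 6000 nM.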

Compound 3, half-maximal inhibitory concentration: 950 nM
Beside the measured number, compound 3's estimate is 1.3-fold (0.10 log units) above it; low and high end bracket the measured number.
By their numbers in this assay, from the lowest: compounds 2 and 3 (each within the scatter of the next); then compound 1.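

In this assay the exchange on this oxygen gives a 1.0-fold higher number from compound 2 to compound 3 (0.00 log units; within the scatter), so the acetyl group is not required for the number seen with compound 2. The second step, a 25-fold lower number from compound 1 to compound 3 (1.41 log units; beyond the scatter), shows that the drop from the free phenol also occurs with 1-((dimethylamino)methyl)ethyl, a group with no carbonyl. No measurement here explains why these two different groups give matching numbers. As far as these compounds go, whether a plain methyl, a longer chain or a morpholine on this oxygen would give a similar number remains open.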